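Aryl replacement at the amide nitrogen, compound 1 to 3

The compounds below may be only part of what the source reports. "The series", "measured", "known", "first", "only" and "open" are said of these compounds alone.

For the measured compounds named here, compound 1 `Cc1cc(C)cc(NC(=O)CN2CCC(c3cccc[n+]3[O-])CC2)c1` holds the lower of the two numbers so far in a functional assay on HEK293 cells for agonist activity at D(4) dopamine receptor (Homo sapiens), read by FLIPR; a higher number here means that more compound is needed for the effect, a lower number that less compound is needed: compound 1 gives 52 nM, while compound 2 `Cc1cc(C)cc(C(=O)NCN2CCC(c3cccc[n+]3[O-])CC2)c1` gives 90 nM, a gap within the scatter, so no order between the two can be claimed. Compound 3 `Cc1cc(F)ccc1NC(=O)CN1CCC(c2cccc[n+]2[O-])CC1` carries 4-fluoro-2-methylphenyl in place of 3,5-dimethylphenyl on an amide-type nitrogen. Going by the values given here, no measured pair in this set shows a change of this kind, so its size is open; a step of modest size is expected, more likely toward a higher number than a lower one, and quite possibly not beyond the scatter. The estimate for compound 3 in this assay is 80 nM, with a range from 25 nM to 250 nM. That estimate corresponds to an expected step of a 1.5-fold higher number from compound 1 to compound 3 (0.19 log units; within the scatter).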

Compound 3, half-maximal effective concentration: 60 nM
Compound 3: the middle estimate sits 1.3-fold (0.12 log units) above what was measured, within the range that was stated.
By their numbers in this assay, from the lowest: compounds 1, 3 and 2 (each within the scatter of the next).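

Putting 4-fluoro-2-methylphenyl in place of 3,5-dimethylphenyl on the amide-type nitrogen gives a 1.2-fold higher number from compound 1 to compound 3 (0.06 log units; within the scatter) in this assay. For the compounds shown here, this is the first pair that differs in one place, and it shows that this position accepts this exchange of substituted phenyl groups with no step that can be told from the scatter. Nothing at hand bears on why the number holds.

The two phenyl groups compared carry only methyl and fluoro substituents. On these data alone, whether a phenyl group carrying an amine or a carboxylic acid would leave the number in the same region remains open.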